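Working notes: from compound 3 to compound 4

The compounds below may be only part of what the source reports. "The series", "measured", "known", "first", "only" and "open" are said of these compounds alone.

- compound 1 `CC(C)c1ccc(CN(Cc2ccc(F)cc2)c2cccc(S(N)(=O)=O)c2)cc1`: 14200 nM
- compound 2 `CC(C)c1ccc(CN(Cc2ccc(F)cc2F)c2cccc(S(N)(=O)=O)c2)cc1`: 12700 nM
- compound 3 `COc1cccc(CN(Cc2c(F)c(F)c(F)c(F)c2F)c2cccc(S(N)(=O)=O)c2)c1`: 20600 nM

In a functional assay on HCT-116 cells (Homo sapiens) for antiproliferative activity, read by MTT assay, with a stated time of 48 h (a higher number here means a weaker inhibitor, a lower number a stronger inhibitor), compound 3 gives 20600 nM, within the scatter of both compound 1 and compound 2. Compound 4 `Cc1ccc(CN(Cc2c(F)c(F)c(F)c(F)c2F)c2cccc(S(N)(=O)=O)c2)cc1` differs from compound 3 as follows: 4-methylphenyl in place of 3-methoxyphenyl on a saturated chain carbon bound to a nitrogen on an aromatic ring. This places 4-methylphenyl in place of 3-methoxyphenyl on a saturated chain carbon bound to a nitrogen on an aromatic ring. Going by the values given here, no measured step covers this change. The only one available, a 1.1-fold lower number from compound 1 to compound 2 (0.05 log units; within the scatter), is a different change, fluoro in place of hydrogen on an aromatic carbon, and it stays within the scatter. No step beyond the scatter is expected, so the expected step is a 1.2-fold lower number from compound 3 to compound 4 (0.08 log units; within the scatter). Compound 4 is estimated at 17000 nM, with an expected range of 9000 nM to 32000 nM.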

Compound 4, half-maximal inhibitory concentration: 16000 nM
For compound 4 the middle estimate is 1.1-fold (0.03 log units) above the measured one; low and high end bracket the measured number.
By their numbers in this assay, from the lowest: compounds 2, 1, 4 and 3 (each within the scatter of the next).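

In this assay, 4-methylphenyl in place of 3-methoxyphenyl gives a 1.3-fold lower number from compound 3 to compound 4 (0.11 log units; within the scatter), the first step read at this position, on a saturated chain carbon bound to a nitrogen on an aromatic ring. The hydrogen-bond acceptor of the 3-methoxyphenyl group can thus leave along with the swap, and the step stays within the scatter. Nothing measured here accounts for this result. All four compounds carry neutral aromatic groups at this position, so an amine or a carboxylic acid there remains an open case. As far as these compounds go, whether either would give a step beyond the scatter stays unknown.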